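The source may hold more compounds than are shown below. What is called first, only, known or untested is meant among the compounds shown, and "the series" means these compounds.

In an assay on RAW264.7 cells for antagonist activity at Toll-like receptor 2 (Mus musculus), read by Griess assay, with a stated time of 24 h (a lower number here means a stronger inhibitor, a higher number a weaker inhibitor), compound 1 `C=CCCSC[C@H](N)C(=O)OC` gives 45500 nM. Among the compounds with values here, compound 2 `C=CCCCSC[C@H](N)C(=O)OC` gives 31300 nM, the lowest of the two numbers measured so far; its only neighbour is compound 1, and the step of a 1.5-fold lower number from compound 1 to compound 2 (0.16 log units; within the scatter) lies within the scatter, so the two compounds cannot be ranked against each other. Compound 3 `C#CCSC[C@H](N)C(=O)OC` has not yet been measured. Its difference from compound 2 is ethynyl in place of but-3-en-1-yl on a saturated chain carbon bound to a sulfur, so the unsaturated chain is shortened and its double bond is exchanged for a triple bond. Within the data shown here, the only measured step that bears on this change is the one between compound 1 and compound 2, and it was small: lengthening the unsaturated chain left the number essentially where it was. A step of a 1.4-fold higher number from compound 2 to compound 3 (0.16 log units; within the scatter) in this assay is therefore expected for compound 3, with the direction uncertain and probably nothing beyond the scatter. The number for compound 3 is estimated at 45000 nM, within a range from 15000 nM to 135000 nM.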

Compound 3, half-maximal inhibitory concentration: 94400 nM
Beside the measured number, compound 3's estimate is 2.1-fold (0.32 log units) below it; the range from low to high includes it.
By their numbers in this assay, from the lowest: compounds 2 and 1 (each within the scatter of the next); then compound 3.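

Until now, changing the unsaturated chain on the sulfur had moved the number in this assay by no more than the scatter, so this position looked indifferent to such changes. Within the data shown here, the ethynyl group gives the first changes beyond the scatter, with a 3.0-fold higher number from compound 2 to compound 3 (0.48 log units; beyond the scatter) and a 2.1-fold higher number from compound 1 to compound 3 (0.32 log units; beyond the scatter), so compound 3 is the weakest inhibitor of the three, though both steps are modest. No measurement here offers an explanation for this loss.

The change from compound 2 to compound 3 both shortens the chain and exchanges a double bond for a triple bond, and these compounds cannot show which of the two matters. On these data alone, it also remains open how a longer chain ending in a triple bond, or a fully saturated propyl chain, would compare at this position.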